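HDAC6 series: a cap change on the shared core

A few compounds are considered here, and "the series" means these few. Any claim that something is new, unique, unknown or untested is made for them only; others in the source may bear on it.

Measured compounds:
- compound 1 `Cc1cc(-c2nnc(Sc3c(F)cc(C(=O)NO)cc3F)n2C)nn1C`: 6 nM
- compound 2 `O=C(NO)c1ccc(Cn2nnc(-c3ncccn3)n2)cc1`: 7 nM

In an assay on Sf9 cells for inhibition of protein deacetylase HDAC6 (Homo sapiens), read by fluorescence (on this read-out higher numbers stand for weaker inhibition and lower numbers for stronger inhibition), compound 1 gives 6 nM. In this assay compound 2 gives 7 nM, the higher of the two numbers, but the gap to compound 1 lies within the scatter, so the two values show no order between them.

Compound 3 `NCc1ccc(-c2nnn(Cc3ccc(C(=O)NO)cc3)n2)cc1` has not been measured. It differs from compound 2 in one place: 4-(aminomethyl)phenyl in place of pyrimidin-2-yl on an aromatic carbon. Within the data shown here, no step between measured compounds informs this kind of change, and with only two values on the shared core, both close together, there is no basis for predicting a strong move in either direction. The expectation is that the step from compound 2 to compound 3 in this assay stays close to the scatter, a 1.4-fold higher number from compound 2 to compound 3 (0.15 log units; within the scatter), with some allowance for a weaker number. For compound 3 the estimate in this assay is 10 nM, with a range from 3 nM to 40 nM.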

Compound 3, half-maximal inhibitory concentration: 2 nM
Compound 3: middle estimate off by 5.0-fold (0.70 log units), on the high side; measured number below the stated range.
By their numbers in this assay, from the lowest: compound 3; then compounds 1 and 2 (each within the scatter of the next).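

Among these compounds, on the aromatic carbon of the five-membered aromatic ring with 4 nitrogen, between two ring nitrogen atoms, this is the first change with a step that can be read: in this assay, 4-(aminomethyl)phenyl in place of pyrimidin-2-yl gives a 3.5-fold lower number from compound 2 to compound 3 (0.54 log units; beyond the scatter), a modest move beyond the scatter. The position therefore responds to what it carries, and it accepts the larger group of 8 heavy atoms in place of 6, with a ring of carbon only and a hydrogen-bond donor, without any loss of inhibition. Nothing at hand explains the lower number, and the change replaces the ring and adds the aminomethyl arm in a single step, so the shift cannot be assigned to either part.

Still open, on these data alone, is whether the amine itself matters, which a plain phenyl, a carboxylic acid or a longer chain ending in an amine at the same place would help to settle. Also open, as far as these compounds go, is whether the same exchange would move the number in the same direction on the core of compound 1, since a single step gives no trend.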